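Moving a Fluorine Around an Outer Phenyl Ring

A few compounds are considered here, and "the series" means these few. Any claim that something is new, unique, unknown or untested is made for them only; others in the source may bear on it.

Four compounds share one core and differ only in how two outer rings are attached and where a fluorine sits. Compound 1 `O=c1[nH]cc(S(=O)(=O)Nc2cccc(-c3cn(-c4ccccc4F)nn3)c2)c(=O)[nH]1` carries a 2-fluorophenyl group; in a functional assay on OVCAR-3 cells (Homo sapiens) for antiproliferative activity, read by MTT assay, with a stated time of 24 h (a higher number here means a weaker inhibitor, a lower number a stronger inhibitor), compound 1 gives 12500 nM. Compound 2 `O=c1[nH]cc(S(=O)(=O)Nc2cccc(-c3cn(-c4cccc(F)c4)nn3)c2)c(=O)[nH]1` carries a 3-fluorophenyl group instead, the change being (3-fluorophenyl in place of 2-fluorophenyl on an aromatic nitrogen). For compound 2 this assay reports only a limit, > 20000 nM, not a number. The measured step is therefore an at least 1.6-fold higher number from compound 1 to compound 2 (0.20 log units; that floor lies within the scatter), a floor that rests on (the limit of > 20000 nM in this assay, at which 1 of the 3 values shown sits).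

Compound 3 `O=c1[nH]cc(S(=O)(=O)Nc2ccc(-c3cn(-c4ccccc4F)nn3)cc2)c(=O)[nH]1` has a different arrangement of the same atoms; how its core differs from that of compound 1 is not broken down here. In this assay compound 3 gives 8030 nM, which is within the usual scatter of the number for compound 1.

Compound 4 `O=c1[nH]cc(S(=O)(=O)Nc2ccc(-c3cn(-c4cccc(F)c4)nn3)cc2)c(=O)[nH]1` is not yet measured. It differs from compound 3 by 3-fluorophenyl in place of 2-fluorophenyl on an aromatic nitrogen, the same change, at the same place, as that from compound 1 to compound 2. Because the measured step of an at least 1.6-fold higher number from compound 1 to compound 2 (0.20 log units; that floor lies within the scatter) went toward a weaker inhibitor, and because compound 3 starts at 8030 nM, a similar step is expected here, giving an estimated change of a 2.2-fold higher number from compound 3 to compound 4 (0.35 log units; beyond the scatter). Compound 4 is therefore expected to come out near 18000 nM, with a plausible range from 8000 nM to 45000 nM, and a real chance that this assay again reports only a limit.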

Compound 4, half-maximal inhibitory concentration: > 20000 nM
Compound 4 gave a limit, no number; the forecaster's own chance of this, stated with the estimate: 45%; middle value at least 1.1-fold (0.04 log units) away from the limit.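

In this assay, replacing the 2-fluorophenyl group of compound 3 with a 3-fluorophenyl group gives an at least 2.4-fold higher number from compound 3 to compound 4 (0.39 log units; beyond the scatter), and on this core even that minimum step lies beyond the usual scatter. On the core of compound 1, the same change gave an at least 1.6-fold higher number from compound 1 to compound 2 (0.20 log units; that floor lies within the scatter), so both steps point toward a weaker inhibitor, but only the second is shown to exceed the scatter, and the true size of neither step is known, which means this pair cannot show that the change has the same effect on both cores: the same change on two cores in this assay, an at least 1.6-fold higher number (0.20 log units; that floor lies within the scatter) from compound 1 to compound 2 and an at least 2.4-fold higher number (0.39 log units; beyond the scatter) from compound 3 to compound 4; the limit leaves it open whether they differ. Compound 2 and compound 4 each have a limit rather than a number, so these results cannot place the two compounds relative to each other: the limit of > 20000 nM in this assay, at which 2 of the 4 values shown sit.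

The compounds shown leave open what would happen if the fluorine on the outer phenyl ring were replaced by a different group, such as an amine, a methoxy group or a carboxylic acid. They also leave open whether any such replacement would act in the same direction on both cores.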